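Pentyl addition across two related cores

The compounds below may be only part of what the source reports. "The series", "measured", "known", "first", "only" and "open" are said of these compounds alone.

Compound 1 `CCCNC(=O)c1cc(-n2cc(-c3ccccc3)nn2)ccc1O` and compound 3 `CCCNC(=O)c1ccc(-n2cc(-c3ccccc3)nn2)cc1O` are built from the same atoms joined differently; the difference between the two cores is not broken down here. In a functional assay on RAW264.7 cells (Mus musculus) for inhibition, read by Griess assay, with a stated time of 20 h (a lower number here means a stronger inhibitor, a higher number a weaker inhibitor), compound 1 gives > 20000 nM, which is a limit of the assay and not a number. Compound 3 likewise gives only a limit, > 20000 nM. Compound 2 `CCCCCc1ccc(-c2cn(-c3ccc(O)c(C(=O)NCCC)c3)nn2)cc1` carries the change pentyl in place of hydrogen on an aromatic carbon on the core of compound 1. Compound 2 also sits at a limit, > 20000 nM. The step that the two limits leave unreadable from compound 1 to compound 2 cannot be read because the limit of > 20000 nM in this assay, at which 3 of the 3 values shown sit, holds every value shown. Compound 4 `CCCCCc1ccc(-c2cn(-c3ccc(C(=O)NCCC)c(O)c3)nn2)cc1` carries the same change on the core of compound 3, (pentyl in place of hydrogen on an aromatic carbon), at a place described in the same words. With nothing readable from the earlier step, compound 4 is expected to stay at the limit, so the step that the limit leaves unreadable from compound 3 to compound 4 is estimated as within scatter. Compound 4 is estimated at 35000 nM, between 15000 nM and 150000 nM.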

Compound 4, half-maximal inhibitory concentration: > 20000 nM
Compound 4: a limit, no number (the forecaster's own chance of this, stated with the estimate: 85%); the middle value is on the limit's open side.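

No step can be read from compound 3 to compound 4, because both values are limits and not numbers: the limit of > 20000 nM in this assay, at which 4 of the 4 values shown sit.

The compounds shown leave open whether pentyl in place of hydrogen on an aromatic carbon changes inhibition on either core.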